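Fluoro for methoxy: estimate for compound 4

The source may hold more compounds than are shown below. What is called first, only, known or untested is meant among the compounds shown, and "the series" means these compounds.

Measured so far in an assay on HeLa cells for displacement of a labelled ligand from 5-hydroxytryptamine receptor 6 (Homo sapiens), with a stated time of 2 h; a lower number here means a stronger inhibitor, a higher number a weaker inhibitor:
- compound 1 `COc1ccc2c(c1)c(S(=O)(=O)c1cccc(F)c1)cn2C1CCCNC1`: 10.7 nM
- compound 2 `O=S(=O)(c1ccccc1)c1cn(C2CCN(Cc3ccccc3)C2)c2ccccc12`: 113 nM
- compound 3 `O=S(=O)(c1cccc(F)c1)c1cn(C2CCNC2)c2cc(Cl)ccc12`: 72 nM

Compound 1 stands lowest of the three numbers; compound 3 lies beyond the scatter from it, and compound 2 lies further still. Compound 4 `O=S(=O)(c1cccc(F)c1)c1cn(C2CCCNC2)c2ccc(F)cc12` differs from compound 1 by fluoro in place of methoxy on an aromatic carbon. Among the measured compounds shown here, no pair of measured compounds isolates this change, so the size of the step rests on expectation alone. Methoxy and fluoro are both small groups at the same place on the shared core, so a modest step is expected, slightly toward a weaker binder, about a 2.3-fold higher number from compound 1 to compound 4 (0.37 log units; beyond the scatter). Compound 4 is expected to give about 25 nM in this assay, in the range 8 nM to 80 nM.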

Compound 4, inhibition constant: 4 nM
For compound 4 the middle estimate is 6.3-fold (0.80 log units) above the measured one, outside the stated range (below it).
By their numbers in this assay, from the lowest: compound 4; then compound 1; then compounds 3 and 2 (each within the scatter of the next).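

In this assay, among the compounds shown here, fluoro in place of methoxy on this aromatic carbon gives a 2.7-fold lower number from compound 1 to compound 4 (0.43 log units; beyond the scatter) and is the first single-place step. The methoxy group, with its oxygen acceptor and extra heavy atom, is therefore not required for a low number at this position on the shared core. Nothing measured here accounts for the step.

Going by these compounds, how a nitrile, a hydroxyl or an amine on the same carbon would read remains open. On these data alone, whether the step carries over to other cores also remains open, since this single pair cannot show it.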